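A few compounds are considered here, and "the series" means these few. Any claim that something is new, unique, unknown or untested is made for them only; others in the source may bear on it.

Measured so far in a functional assay on the whole organism (strain Swiss) with Mus musculus as the target, in the maximal electroshock model, with a stated time of 0.5 h, at a dose of 300 mg/kg by the intraperitoneal route; a higher number here means a stronger effect of the compound at the dose given, a lower number a weaker effect:
compound 1, `CCC(C(=O)N1CCN(c2cccc(F)c2)CC1)N1C(=O)CCC1=O`, gives 100%
compound 2, `CCC(C(=O)N1CCN(c2ccc(F)cc2)CC1)N1C(=O)CCC1=O`, gives 25%
compound 3, `CC(C(=O)N1CCN(c2ccc(F)cc2)CC1)N1C(=O)CCC1=O`, gives 50%

Compound 4, `CC(C(=O)N1CCN(c2cccc(F)c2)CC1)N1C(=O)CCC1=O`, remains to be measured. It differs from compound 3 by 3-fluorophenyl in place of 4-fluorophenyl on an amine nitrogen in a ring. The same change is made from compound 2 to compound 1, (3-fluorophenyl in place of 4-fluorophenyl on an amine nitrogen in a ring), where the step in this assay was a number 75 percentage points higher from compound 2 to compound 1 (beyond the scatter). The cores of compound 2 and compound 3 differ by hydrogen in place of methyl on a saturated chain carbon, two bonds along the chain from an amide-type nitrogen in a ring and a carbonyl carbon, a change that on its own gave a number 25 percentage points higher from compound 2 to compound 3 (beyond the scatter). Compound 3 already stands at 50%, so a rise of the earlier size is not possible within the read-out. On the strength of a number 75 percentage points higher from compound 2 to compound 1 (beyond the scatter), a step of a number 40 percentage points higher from compound 3 to compound 4 (beyond the scatter) is expected. Compound 4 is estimated at 90%, with a range from 65% to 100%.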

Compound 4, a percentage reported as activity, at one dose (the size of the read-out at that dose, not a potency): 50%
Beside the measured number, compound 4's estimate is 40 percentage points above it, and the stated range ends above it.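

In this assay, 3-fluorophenyl in place of 4-fluorophenyl gives no change at the digits printed from compound 3 to compound 4 (within the scatter), so the gain seen on the core of compound 1 does not carry over to the core of compound 4: the same change on two cores in this assay, a number 75 percentage points higher (beyond the scatter) from compound 2 to compound 1 and no change at the digits printed (within the scatter) from compound 3 to compound 4, 75 percentage points apart, beyond the scatter of two such steps. Hydrogen in place of methyl on the saturated chain carbon likewise depends on the aryl group, with a number 50 percentage points lower from compound 1 to compound 4 (beyond the scatter) set against the earlier rise: the same change on two cores in this assay, a number 25 percentage points higher (beyond the scatter) from compound 2 to compound 3 and a number 50 percentage points lower (beyond the scatter) from compound 1 to compound 4, 75 percentage points apart, beyond the scatter of two such steps. These two pairs, read at a single dose, show that the two changes do not act independently in this series, but they do not show why, and they give no potency.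

Still open, from the compounds shown here alone, is whether a propyl chain on that saturated chain carbon would follow compound 1 or compound 4. The same question stands for chlorine in place of fluorine on the phenyl ring.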